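Urea to Benzamide on the Shared Core

The compounds below may be only part of what the source reports. "The series", "measured", "known", "first", "only" and "open" are said of these compounds alone.

Compound 1 `COc1cc(-c2nn(-c3cccc(NC(=O)Nc4ccc(Cl)c(Cl)c4)c3)cc2-c2ccncc2)ccc1Cl` was tested in a functional assay on HOP-62 cells (Homo sapiens) for inhibition, read by sulforhodamine B assay, with a stated time of 48 h (a lower number here means that less compound is tolerated, a higher number that more compound is tolerated), and gave only a limit, > 50000 nM, so its true position is not fixed by a number. Among the two values shown it sits at the limit of > 50000 nM in this assay, at which 1 of the 2 values shown sits, which is the one value that is a limit rather than a measurement. Within the data shown here, compound 2 `O=C(Nc1cccc(-n2cc(-c3ccncc3)c(-c3ccc(Cl)c(O)c3)n2)c1)Nc1cc(C(F)(F)F)cc(C(F)(F)F)c1`, which carries a different core and a different aryl urea, gives 4070 nM in this assay; no single-point step connects it to compound 1, so only the two values themselves can be compared.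

Compound 3 `COc1cc(-c2nn(-c3cccc(NC(=O)c4ccccc4)c3)cc2-c2ccncc2)ccc1Cl` is not yet measured. It differs from compound 1 in one place: phenyl in place of (3,4-dichlorophenyl)amino on a carbonyl carbon. The urea of compound 1 becomes a benzamide, and the two chlorine atoms on the outer ring go with it.

Among the measured compounds shown here, with compound 1 itself at a limit, no measured step on this core is available to guide the expectation. Compound 3 is therefore expected to remain near the same region, a step of about a number no higher from compound 1 to compound 3 (the limit leaves the size open), with an estimated value of 50000 nM in a range from 10000 nM to 150000 nM, and a real chance that this assay again reports only a limit.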

Compound 3, concentration lethal to 50% of the cells: > 100000 nM
Compound 3 gave a limit, no number; the forecaster's own chance of this, stated with the estimate: 65%; at least 2.0-fold (0.30 log units) between middle value and limit.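

In this assay compound 3 gives > 100000 nM, which is a limit of the assay. Compound 1 also gives only a limit, > 50000 nM, and the step between compound 1 and compound 3 cannot be read. The compounds shown leave open how far phenyl in place of (3,4-dichlorophenyl)amino on a carbonyl carbon moves the value on the shared core, or in which direction.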